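The source may report more compounds than this note shows. Statements on the series, on what has been measured and on what is new or still open speak of the compounds shown alone.

Measured so far in an assay for inhibition of mitogen-activated protein kinase kinase kinase 14 (Homo sapiens), read by luminescence and ADP-Glo, with a stated time of 120 min, in the presence of a further agent that is not named here; a lower number here means a stronger inhibitor, a higher number a weaker inhibitor:
- compound 1 `C[C@H]1CN(c2ccc(C#CC(C)(O)c3nccs3)cc2Nc2ncnc3[nH]ccc23)CCN1` gives 69.2 nM
- compound 2 `CN1CCN(c2ccc(C#CC(C)(O)c3nccs3)cc2Nc2ncnc3[nH]ccc23)CC1` gives 78.3 nM
- compound 3 `CCN1CCN(c2ccc(C#CC(C)(O)c3nccs3)cc2Nc2ncnc3[nH]ccc23)CC1` gives 34.5 nM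

Compound 3 carries the lowest number of the three. Its gap to compound 1 is within the scatter (a 2.0-fold lower number from compound 1 to compound 3 (0.30 log units; within the scatter)), while its gap to compound 2 is beyond it (a 2.3-fold lower number from compound 2 to compound 3 (0.36 log units; beyond the scatter)).

Compound 4 `CN1CCCN(c2ccc(C#CC(C)(O)c3nccs3)cc2Nc2ncnc3[nH]ccc23)CC1` differs from compound 3 by 4-methyl-1,4-diazepan-1-yl in place of 4-ethylpiperazin-1-yl on an aromatic carbon. The three steps measured so far all alter the same saturated ring substituent and stay small: a 1.1-fold higher number from compound 1 to compound 2 (0.05 log units; within the scatter), a 2.0-fold lower number from compound 1 to compound 3 (0.30 log units; within the scatter), and the modest 2.3-fold lower number from compound 2 to compound 3 (0.36 log units; beyond the scatter). Within the data shown here, the move to a seven-membered ring with a methyl on the amine nitrogen has no measured counterpart, so a step within the scatter is expected in this assay, if anything toward a slightly higher number, which is the direction of compound 2.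

The expected step is a 1.6-fold higher number from compound 3 to compound 4 (0.20 log units; within the scatter). Compound 4 is estimated at 55 nM, with a range of 25 nM to 120 nM.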

Compound 4, half-maximal inhibitory concentration: 60.1 nM
For compound 4 the middle estimate is 1.1-fold (0.04 log units) below the measured one, within the range that was stated.
By their numbers in this assay, from the lowest: compounds 3, 4, 1 and 2 (each within the scatter of the next, the first and the last beyond it).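

In this assay, the seven-membered 4-methyl-1,4-diazepan-1-yl ring at this aromatic carbon is tolerated alongside all three six-membered rings: a 1.7-fold higher number from compound 3 to compound 4 (0.24 log units; within the scatter), a 1.3-fold lower number from compound 2 to compound 4 (0.11 log units; within the scatter) and a 1.2-fold lower number from compound 1 to compound 4 (0.06 log units; within the scatter) are each within the scatter. Among these compounds, ring size at this position therefore has no effect that the assay can resolve. No measurement at hand bears on the reason for this.

Open, on these data alone, is whether a morpholine or an open-chain dimethylamino group would stay in the same band. Also open, as far as these compounds go, is whether 4-ethyl-1,4-diazepan-1-yl would.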